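Ring amine replacements at the core of compound 1

The source may hold more compounds than are shown below. What is called first, only, known or untested is meant among the compounds shown, and "the series" means these compounds.

Compound 1 `O=C(CCc1ccc(C(F)(F)F)cc1)Nc1ccc2nc(N3CCC3)ccc2c1` carries an azetidin-1-yl group on the shared core. Among the measured compounds shown here, in an assay on isolated protein for displacement of a labelled ligand from melanin-concentrating hormone receptor 1 (Homo sapiens) (on this read-out lower numbers stand for stronger inhibition and higher numbers for weaker inhibition), compound 1 gives 4 nM, the lowest of the three numbers measured so far. Compound 2 `CN(c1ccc2cc(NC(=O)CCc3ccc(C(F)(F)F)cc3)ccc2n1)C1CCCCC1` gives 18 nM, and compound 3 `CC1CCCN1c1ccc2cc(NC(=O)CCc3ccc(C(F)(F)F)cc3)ccc2n1` gives 5 nM. Compound 4 `CNC(=O)NC1CCN(c2ccc3cc(NC(=O)CCc4ccc(C(F)(F)F)cc4)ccc3n2)C1` has not yet been measured; it differs from compound 1 by 3-((methylcarbamoyl)amino)pyrrolidin-1-yl in place of azetidin-1-yl on an aromatic carbon.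

For the measured compounds named here, two measured steps bear on this change. The move to a pyrrolidin-1-yl ring with a methyl group, a 1.3-fold higher number from compound 1 to compound 3 (0.10 log units; within the scatter), shows that a five-membered ring in place of azetidin-1-yl is tolerated. The bulkier cyclohexyl(methyl)amino replacement, a 4.5-fold higher number from compound 1 to compound 2 (0.65 log units; beyond the scatter), costs a modest amount. The 3-((methylcarbamoyl)amino)pyrrolidin-1-yl group is larger than either, so a small loss is expected, comparable to or somewhat smaller than that seen for compound 2, rather than none beyond the scatter. Compound 4 is therefore estimated at 9 nM in this assay, with a plausible range of 3 nM to 30 nM, which corresponds to an expected step of a 2.3-fold higher number from compound 1 to compound 4 (0.35 log units; beyond the scatter).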

Compound 4, half-maximal inhibitory concentration: 6 nM
Beside the measured number, compound 4's estimate is 1.5-fold (0.18 log units) above it; low and high end bracket the measured number.
By their numbers in this assay, from the lowest: compounds 1, 3 and 4 (each within the scatter of the next); then compound 2.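

In this assay, the 3-((methylcarbamoyl)amino)pyrrolidin-1-yl group on the aromatic carbon next to the ring nitrogen stays level with azetidin-1-yl, a 1.5-fold higher number from compound 1 to compound 4 (0.18 log units; within the scatter), and with 2-methylpyrrolidin-1-yl, a 1.2-fold higher number from compound 3 to compound 4 (0.08 log units; within the scatter). This position therefore accepts a substituted five-membered ring bearing hydrogen-bond donors, and the loss seen with cyclohexyl(methyl)amino does not extend to every larger group, as a 3.0-fold lower number from compound 2 to compound 4 (0.48 log units; beyond the scatter) shows. No supporting data explain this difference between the two larger groups.

The compounds shown leave open whether the methylcarbamoyl part affects the number at all, since an unsubstituted pyrrolidin-1-yl or a 3-aminopyrrolidin-1-yl group would separate it from the ring. On these data alone, it also remains open whether a carboxylic acid at the same ring carbon would fit equally well.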